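The source may hold more compounds than are shown below. What is called first, only, known or untested is meant among the compounds shown, and "the series" means these compounds.

Series notes, antagonist maximal response.

Compound 1 `CO[C@@H]1CN(CC2Cc3ccccc3C2)CC[C@H]1n1c(C)nc2cc(C)ccc21` gives in a functional assay for antagonist activity at melanin-concentrating hormone receptor 1 (Homo sapiens), read by cAMP accumulation (on this read-out higher numbers stand for larger maximal responses and lower numbers for smaller maximal responses), a value of 90%. Compound 2 `CO[C@@H]1CN(C[C@H]2Cc3ccc(Br)cc3C2)CC[C@H]1n1c(C)nc2cc(C)ccc21`, carrying bromo in place of hydrogen on an aromatic carbon, gives in this assay a value of 92%. The step of a number 2 percentage points higher from compound 1 to compound 2 (within the scatter) lies within the scatter, so the two compounds are treated as equal in maximal response. Compound 2 therefore holds the higher of the two numbers recorded, but only by a margin that the scatter covers.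

Compound 3 `COC(=O)Nc1ccc2c(c1)C[C@@H](CN1CC[C@@H](n3c(C)nc4cc(C)ccc43)[C@H](OC)C1)C2` follows from compound 2 by the change ((methoxycarbonyl)amino in place of bromo on an aromatic carbon). Within the data shown here, the one measured step in the set, a number 2 percentage points higher from compound 1 to compound 2 (within the scatter), also concerns a substituent entering at an aromatic carbon of the same ring and produced no shift beyond the scatter. Among the measured compounds shown here, no measured step involves a (methoxycarbonyl)amino group, so nothing points to a change in maximal response. The step from compound 2 to compound 3 is therefore expected to be small, a number 2 percentage points lower from compound 2 to compound 3 (within the scatter), with no direction favoured beyond the scatter. Compound 3 is estimated at 90%, in the range 78% to 100%.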

Compound 3, largest response reached (reported as efficacy), in percent of the reference or control that the assay uses: 81%
Estimate against measurement, compound 3: 9 percentage points above, within the range that was stated.
By their numbers in this assay, from the lowest: compounds 3, 1 and 2 (each within the scatter of the next, the first and the last beyond it).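

At this carbon of the six-membered aromatic ring, the change from bromo to (methoxycarbonyl)amino gives the first shift beyond the scatter in this assay, with a number 11 percentage points lower from compound 2 to compound 3 (beyond the scatter) as the step. Set against hydrogen at the same carbon, a number 9 percentage points lower from compound 1 to compound 3 (within the scatter) remains within the scatter, so the series separates compound 3 from compound 2 but not from compound 1, and the substituent's influence on maximal response is only modest. No measurement here accounts for the difference between bromo and (methoxycarbonyl)amino.

On these data alone, it remains open whether an amine or an acetylamino group at this carbon would align with compound 3 or compound 2. Also open, as far as these compounds go, is whether a longer chain in place of the methyl of the (methoxycarbonyl)amino group would shift the response further.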